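The compounds below may be only part of what the source reports. "The series", "measured", "known", "first", "only" and "open" are said of these compounds alone.

In an ADME assay on HepG2 cells (Homo sapiens), read by MTT assay, with a stated time of 72 h, in the presence of a further agent that is not named here (a higher number here means a weaker inhibitor, a lower number a stronger inhibitor), compound 1 `O=C(Nc1ccccc1)Oc1ccc(Cl)cc1C(=O)Nc1ccc(F)cc1` gives 3250 nM, and compound 2 `O=C(Nc1ccccc1)Oc1ccc(Cl)cc1C(=O)Nc1ccc(Br)cc1` gives 5450 nM. With only these two numbers measured, compound 2 stands within the scatter of compound 1, so neither can be ranked above the other. Compound 3 `O=C(Nc1ccccc1)Oc1ccc(Cl)cc1C(=O)Nc1ccc(Cl)cc1` differs from compound 2 by one swap: chloro in place of bromo on an aromatic carbon. The new chloro sits on an aromatic carbon, para to a large group. Within the data shown here, the only measured step that bears on this swap, bromo in place of fluoro on an aromatic carbon, is a 1.7-fold higher number from compound 1 to compound 2 (0.22 log units; within the scatter). That step is small, so no change beyond the scatter is expected in this assay. The expected step is a 1.3-fold lower number from compound 2 to compound 3 (0.11 log units; within the scatter). For compound 3 the estimated value is 4200 nM, with an expected range of 2100 nM to 8400 nM.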

Compound 3, half-maximal inhibitory concentration: 900 nM
Compound 3: middle estimate off by 4.7-fold (0.67 log units), on the high side; the measured number lies below the stated range.
By their numbers in this assay, from the lowest: compound 3; then compounds 1 and 2 (each within the scatter of the next).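

The earlier step between fluoro and bromo suggested that this position tolerates a change of halogen with little effect, but chloro breaks that picture. In this assay, there is a 6.1-fold lower number from compound 2 to compound 3 (0.78 log units; beyond the scatter) and a 3.6-fold lower number from compound 1 to compound 3 (0.56 log units; beyond the scatter), so the swap of one halogen atom on an aromatic carbon, para to a large group, can move the number beyond the scatter. Taken in the order fluoro, chloro, bromo, the three values do not run in one direction, and no information at hand accounts for the lower number with chloro.

On these data alone, the three compounds cover only halogens at this position, so it remains open whether the lower number belongs to chloro alone. Iodo, methyl, methoxy or an amine in the same place could land on either side of it.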